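A few compounds are considered here, and "the series" means these few. Any claim that something is new, unique, unknown or untested is made for them only; others in the source may bear on it.

Measured so far in an ADME assay on MT4 cells (Homo sapiens) for cytotoxicity, read by MTT assay, with a stated time of 96 h; on this read-out higher numbers stand for lower toxicity in this test and lower numbers for higher toxicity in this test:

compound 1, `Cc1ccccc1C1CC(c2ccc(OCc3ccccc3)cc2)=NN1c1ccc(S(N)(=O)=O)cc1`: >= 100000 nM, which is a limit of the assay rather than a number
compound 2, `Cc1ccccc1C1CC(c2ccccc2)=NN1c1ccc(S(N)(=O)=O)cc1`: 43000 nM

Compound 1 stands at the limit of the assay, with the evidence (the limit of >= 100000 nM in this assay, at which 1 of the 2 values shown sits); its number is therefore known only as a bound, not as a point. Going by the values given here, the one measured step, an at least 2.3-fold lower number from compound 1 to compound 2 (0.36 log units; beyond the scatter), concerns the benzyloxy group only.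

Compound 3, `NS(=O)(=O)c1ccc(N2N=C(c3ccc(OCc4ccccc4)cc3)CC2c2cccc(F)c2)cc1`, is not yet measured in this assay. It differs from compound 1 by 3-fluorophenyl in place of 2-methylphenyl on a saturated ring carbon. Among the compounds with values here, the benzyloxy group is kept in compound 3, so the step from compound 1 to compound 2 does not bear on this change; no measured step touches the saturated ring carbon that carries the aryl group. With nothing to point to, the expectation for the step of a number no higher from compound 1 to compound 3 (the limit leaves the size open) is that it stays within the scatter, in no clear direction. Compound 3 is thus estimated at 100000 nM in this assay, with a range from 40000 nM to 250000 nM, and it may again come back only as a limit.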

Compound 3, half-maximal cytotoxic concentration: 65000 nM
Beside the measured number, compound 3's estimate is 1.5-fold (0.19 log units) above it, within the range that was stated.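

In this assay, the saturated ring carbon next to the ring nitrogen now has a point value with the benzyloxy group kept: compound 3 gives 65000 nM. Placing 3-fluorophenyl there instead of 2-methylphenyl gives an at least 1.5-fold lower number from compound 1 to compound 3 (0.18 log units; that floor lies within the scatter), so this change is not shown to move the number beyond the scatter, although a larger step is not excluded. The true size of the step cannot be read, because compound 1 is held at a limit rather than a number: the limit of >= 100000 nM in this assay, at which 1 of the 3 values shown sits.

The exchange alters both the group on the aryl ring and its place, so the compounds shown do not separate the loss of methyl from the arrival of fluorine, and they leave open what a plain phenyl, or an amine or a carboxylic acid on that aryl ring, would do at this carbon. Also open, as far as these compounds go, is whether hydrogen in place of benzyloxy would act the same way with 3-fluorophenyl on the saturated ring carbon as with 2-methylphenyl.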